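Changing the End Group of Compound 3

The compounds below may be only part of what the source reports. "The series", "measured", "known", "first", "only" and "open" are said of these compounds alone.

In a functional assay on PC-3 cells (Homo sapiens) for inhibition, read by sulforhodamine B assay (on this read-out higher numbers stand for weaker inhibition of growth and lower numbers for stronger inhibition of growth), compound 3 `Oc1cccc2[nH]c(-c3ccc(-c4ccc(-c5ccc(F)cc5)cc4)cc3)nc12` gives 15300 nM, the second highest of three numbers. Compound 2 `Fc1ccc(-c2ccc(-c3ccc(-c4nc5ccccc5[nH]4)cc3)cc2)cc1` sits higher at 41200 nM, and compound 1 `COc1ccc(-c2ccc(-c3ccc(-c4nc5cc(C)ccc5[nH]4)cc3)cc2)cc1OC` sits lower at 2560 nM. Compound 4 `Oc1cccc2[nH]c(-c3ccc(-c4ccc(-c5cccc(Cl)c5)cc4)cc3)nc12` carries 3-chlorophenyl in place of 4-fluorophenyl on an aromatic carbon. Among the measured compounds shown here, no measured step covers this swap. For the measured compounds named here, the only single change measured, hydroxy in place of hydrogen on an aromatic carbon, gave a 2.7-fold lower number from compound 2 to compound 3 (0.43 log units; beyond the scatter), a modest step that bears on it only loosely. A similarly modest shift is therefore expected, tentatively downward, as a 1.5-fold lower number from compound 3 to compound 4 (0.18 log units; within the scatter). For compound 4 the estimated value is 10000 nM, with an expected range from 3000 nM to 35000 nM.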

Compound 4, concentration for 50% growth inhibition: 2560 nM
Compound 4: the middle estimate sits 3.9-fold (0.59 log units) above what was measured; measured number below the stated range.
By their numbers in this assay, from the lowest: compounds 1 and 4 (each within the scatter of the next); then compound 3; then compound 2.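

In this assay, the group on this aromatic carbon clearly counts: 3-chlorophenyl in place of 4-fluorophenyl gives a 6.0-fold lower number from compound 3 to compound 4 (0.78 log units; beyond the scatter). Among the compounds shown here, the earlier compounds showed only a hydroxy change elsewhere on the molecule, so this is the first measured step at this position. No evidence at hand explains why the number falls. The swap alters both the halogen and where it sits, so these two changes remain unseparated. As far as these compounds go, how a phenyl ring carrying an amine or a carboxylic acid would read here also stays open.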